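A few compounds are considered here, and "the series" means these few. Any claim that something is new, unique, unknown or untested is made for them only; others in the source may bear on it.

Working notes on the series. In a functional assay on KB cells (Homo sapiens) for inhibition, read by sulforhodamine B assay (on this read-out lower numbers stand for stronger inhibition of growth and higher numbers for weaker inhibition of growth), compound 1 (`Cc1ccc2[nH]c(-c3ccc(-c4ccc(-c5ccc(N(C)C)cc5)cc4)cc3)nc2c1`) gives 6240 nM, the lowest of three numbers and beyond the scatter of the other two. Compound 3 (`CN(C)c1ccc(-c2ccc(-c3ccc(-c4nc5ccccc5[nH]4)cc3)cc2)cc1`) gives 39300 nM, and compound 2 (`COc1ccc(-c2ccc(-c3ccc(-c4nc5ccccc5[nH]4)cc3)cc2)cc1`) gives 47200 nM; these two lie within the scatter of each other.

The next compound is compound 4 (`Cc1ccc2[nH]c(-c3ccc(-c4ccc(-c5ccc(OC(F)(F)F)cc5)cc4)cc3)nc2c1`), which keeps the core of compound 1 and carries trifluoromethoxy in place of dimethylamino on an aromatic carbon.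

For the measured compounds named here, two measured steps bear on this. The closer one, a 1.2-fold lower number from compound 2 to compound 3 (0.08 log units; within the scatter), exchanges methoxy and dimethylamino at the same place and stays within the scatter. Going by the values given here, it is the only measured change at this place, and it does not involve trifluoromethoxy, so it is a loose guide. The other, a 6.3-fold higher number from compound 1 to compound 3 (0.80 log units; beyond the scatter), concerns the methyl group, which compound 4 retains, so the low number of compound 1 may carry over. No step beyond the scatter is therefore expected in this assay, although a wide range is warranted and any drift is more likely upward.

The expected step is a 1.3-fold higher number from compound 1 to compound 4 (0.11 log units; within the scatter). For compound 4 the estimated value is 8000 nM, with an expected range of 2500 nM to 30000 nM.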

Compound 4, concentration for 50% growth inhibition: 41200 nM
The estimate for compound 4 lay 5.2-fold (0.71 log units) below the measured number; the whole stated range lies below it.
By their numbers in this assay, from the lowest: compound 1; then compounds 3, 4 and 2 (each within the scatter of the next).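

In this assay, for the compounds shown here, the place on the six-membered aromatic ring of carbon only, para to a large group, proves able to move the number on the core of compound 1: trifluoromethoxy in place of dimethylamino gives a 6.6-fold higher number from compound 1 to compound 4 (0.82 log units; beyond the scatter), whereas the only earlier change at this place, a 1.2-fold lower number from compound 2 to compound 3 (0.08 log units; within the scatter), showed no step beyond the scatter. The low number of compound 1 therefore does not follow from the methyl group alone, since compound 4 keeps that group; with a 6.3-fold higher number from compound 1 to compound 3 (0.80 log units; beyond the scatter) also on record, a single change at either place takes the number away from compound 1, and among these compounds the low number is seen only with methyl and dimethylamino together. No measurement offered here explains this difference between dimethylamino and trifluoromethoxy.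

From the compounds shown here alone, it remains open whether the low number is specific to dimethylamino or would also appear on the methyl-bearing core with methoxy, diethylamino or a morpholine ring at this place. Also open, going by these compounds, is whether the step for hydrogen in place of methyl would hold with trifluoromethoxy at this place.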